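The compounds below may be only part of what the source reports. "The series", "measured", "known", "first", "only" and "open" are said of these compounds alone.

Measured in a functional assay on HepG2 cells (Homo sapiens) for cytotoxicity, read by WST assay, with a stated time of 24 h; a lower number here means that less compound is tolerated, a higher number that more compound is tolerated:
- compound 1 `CCCC=Cc1cc(-c2ccc3cc(C(=O)O)ccc3c2)ccc1O`: 5.38 ug/mL
- compound 2 `CCCCCCCC=Cc1cc(-c2ccc3cc(C(=O)O)ccc3c2)ccc1O`: 2.6 ug/mL
- compound 3 `O=C(O)c1ccc2cc(-c3ccc(O)cc3)ccc2c1`: > 32 ug/mL, a limit and not a number

Compound 3 has no number in this assay, and its entry of > 32 ug/mL is only a limit. Compound 4 `CCCCCc1cc(-c2ccc3cc(C(=O)O)ccc3c2)ccc1O` differs from it by pentyl in place of hydrogen on an aromatic carbon, ortho to a hydroxy group and meta to a large group (pentyl in place of hydrogen on an aromatic carbon). Going by the values given here, no measured compound carries pentyl itself, so the nearest evidence comes from the two unsaturated chains. Removing them gave an at least 5.9-fold higher number from compound 1 to compound 3 (0.77 log units; beyond the scatter) and an at least 12-fold higher number from compound 2 to compound 3 (1.09 log units; beyond the scatter). Read in reverse, both steps show a chain on this carbon going with a lower number. Chain length also counted, with a 2.1-fold lower number from compound 1 to compound 2 (0.32 log units; beyond the scatter), and the shorter chain of compound 1 at 5.38 ug/mL is the better guide. A step of at least modest size towards a lower number is therefore expected, estimated as an at least 5.3-fold lower number from compound 3 to compound 4 (0.72 log units; beyond the scatter). The estimate for compound 4 is 6 ug/mL. Its expected range runs from 2.5 ug/mL to 15 ug/mL.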

Compound 4, concentration lethal to 50% of the cells: 3.26 ug/mL
Compound 4: the middle estimate sits 1.8-fold (0.26 log units) above what was measured; low and high end bracket the measured number.
By their numbers in this assay, from the lowest: compounds 2, 4 and 1 (each within the scatter of the next, the first and the last beyond it). At a limit, above all of these: compound 3.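

In this assay, the saturated pentyl on this aromatic carbon, ortho to a hydroxy group, shows that a chain here need not carry a double bond to go with a lower number: an at least 9.8-fold lower number from compound 3 to compound 4 (0.99 log units; beyond the scatter). The entry for compound 3 is a limit and not a number, so this step gives only a minimum size: the limit of > 32 ug/mL in this assay, at which 1 of the 4 values shown sits. Replacing either unsaturated chain with pentyl brought no change that can be read, with a 1.7-fold lower number from compound 1 to compound 4 (0.22 log units; within the scatter) and a 1.3-fold higher number from compound 2 to compound 4 (0.10 log units; within the scatter).

What the compounds shown leave open is how short the chain on this carbon can become, for instance ethyl or methyl, before the number rises towards the limit of compound 3. As far as these compounds go, it is also open whether a chain ending in an amine or a carboxylic acid would behave like pentyl.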